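A few compounds are considered here, and "the series" means these few. Any claim that something is new, unique, unknown or untested is made for them only; others in the source may bear on it.

Compounds measured so far in an assay on isolated protein for inhibition of Caspase-8 (Homo sapiens); a higher number here means a weaker inhibitor, a lower number a stronger inhibitor:
- compound 1, `O=C(CN1CC=CC[C@H](NC(=O)c2cc(Cl)ccc2Cl)C1=O)N[C@H]1CC(=O)OC1O`: 554 nM
- compound 2, `O=C(CN1CC=CC[C@H](NC(=O)c2cccc(Cl)c2)C1=O)N[C@H]1CC(=O)OC1O`: 1180 nM

Compound 2 gives the highest of the two numbers in this assay; its nearest neighbour is compound 1, which lies at 554 nM. For the measured compounds named here, the one measured step, a 2.1-fold higher number from compound 1 to compound 2 (0.33 log units; beyond the scatter), is modest and beyond the scatter.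

Compound 3, `O=C(CN1CC=CC[C@H](NC(=O)c2cc3ccccc3s2)C1=O)N[C@H]1CC(=O)OC1O`, is unmeasured. It differs from compound 2 in one place: 1-benzothiophen-2-yl in place of 3-chlorophenyl on a carbonyl carbon. Going by the values given here, no measured pair swaps one aromatic group for another, so the single step between compound 1 and compound 2 bears on this change only loosely, showing that the substituent pattern on that aromatic ring moves the number by a modest amount. A step of similar or smaller size is therefore expected, most likely towards a lower number given that compound 1, the larger-substituted analogue, gives 554 nM. For compound 3 the expected step is a 1.7-fold lower number from compound 2 to compound 3 (0.23 log units; within the scatter), with a wide range. The estimate for compound 3 in this assay is 700 nM, between 200 nM and 2500 nM.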

Compound 3, half-maximal inhibitory concentration: 1450 nM
Compound 3: middle estimate off by 2.1-fold (0.32 log units), on the low side, and the stated range covers the measured number.
By their numbers in this assay, from the lowest: compound 1; then compounds 2 and 3 (each within the scatter of the next).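

In this assay the 1-benzothiophen-2-yl group on a carbonyl carbon gives a 1.2-fold higher number from compound 2 to compound 3 (0.09 log units; within the scatter) so a second aromatic ring and a sulfur atom in place of the chlorine do not separate this group from 3-chlorophenyl at this position. Set against 2,5-dichlorophenyl, the same group gives a 2.6-fold higher number from compound 1 to compound 3 (0.42 log units; beyond the scatter) and compound 1 is thus the only one of the three set apart from both others, a modest separation. Nothing at hand gives a reason for either step.

Whether an aromatic group is needed on this carbonyl carbon stays open, as a cyclohexyl ring or an n-butyl chain is not among these compounds. Also open, on these data alone, is how an amine or a carboxylic acid on the aromatic ring would read in this assay given the small spread so far.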